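Loss of one chloro group from compound 3

The source may report more compounds than this note shows. Statements on the series, on what has been measured and on what is new or still open speak of the compounds shown alone.

Among the measured compounds shown here, compound 3 `Clc1ccc(-c2nc(N3CCCCC3)c3nc[nH]c3n2)cc1Cl` gives 0.7% in an assay on cells for displacement of a labelled ligand from adenosine receptor A2b (Homo sapiens), read by scintillation counting and radioligand binding, with a stated time of 30 min, tested at 10 uM (a lower number here means less inhibition, a higher number more inhibition at the concentration tested (going by the name of the read-out)), the lowest of the three numbers so far: compound 2 `CN1CCN(c2nc(-c3ccc(Cl)c(Cl)c3)nc3[nH]cnc23)CC1` gives 24.1%, higher by a margin beyond the scatter, and compound 1 `Cn1cnc2c(N3CCCCC3)nc(-c3ccccc3O)nc21` gives 30.2%, higher still. For the measured compounds named here, the only measured step, a number 23.4 percentage points lower from compound 2 to compound 3 (beyond the scatter), concerns the amine on the core and not the chloro-bearing ring. Compound 4 `Clc1ccc(-c2nc(N3CCCCC3)c3nc[nH]c3n2)cc1` differs from compound 3 by hydrogen in place of chloro on an aromatic carbon. Going by the values given here, no measured step removes a chloro from this ring, so the change has no direct precedent in the set; with compound 3 already at the floor of the numbers, the expected movement is a number 4.3 percentage points higher from compound 3 to compound 4 (within the scatter), nothing beyond the scatter. Compound 4 is therefore estimated at 5%, within -5% to 20%.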

Compound 4, a percentage reported as inhibition, at one concentration (the size of the read-out at that concentration, not a potency): 1.4%
For compound 4 the middle estimate is 3.6 percentage points above the measured one, and the stated range covers the measured number.
By their numbers in this assay, from the lowest: compounds 3 and 4 (each within the scatter of the next); then compounds 2 and 1 (each within the scatter of the next).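

First measured change on the chloro-bearing ring: in this assay, hydrogen in place of the chloro ortho to a chloro group and meta to a large group gives a number 0.7 percentage points higher from compound 3 to compound 4 (within the scatter), so this chloro can go without a change in the read-out beyond the scatter. Both numbers lie at the low end of the set, which leaves little room to see a drop. No supporting measurement bears on this result. Still open, going by these compounds, is whether the same change holds with 4-methylpiperazin-1-yl on the core, and whether a methoxy group or an amine at this place would raise the number.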